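The source may hold more compounds than are shown below. What is called first, only, known or untested is meant among the compounds shown, and "the series" means these compounds.

Measured compounds in a functional assay on A2780 cells (Homo sapiens) for antiproliferative activity, read by resazurin assay, with a stated time of 72 h; on this read-out higher numbers stand for weaker inhibition and lower numbers for stronger inhibition:
- compound 1 `CN(Cc1ccccc1F)C(=O)c1cc2c(Cc3ccccc3)n[nH]c2cc1O`: 1500 nM
- compound 2 `CN(Cc1ccccc1Cl)C(=O)c1cc2c(Cc3ccccc3)n[nH]c2cc1O`: 1100 nM
- compound 3 `CN(Cc1cccc(Br)c1)C(=O)c1cc2c(Cc3ccccc3)n[nH]c2cc1O`: 7100 nM

Compound 1 stands second highest of the three numbers in this assay. Its nearest neighbour is compound 2, a step of a 1.4-fold lower number from compound 1 to compound 2 (0.13 log units; within the scatter), so the two cannot be told apart. Compound 3 lies furthest away: a 4.7-fold higher number from compound 1 to compound 3 (0.68 log units; beyond the scatter), and from compound 2 the same exchange reads a 6.5-fold higher number from compound 2 to compound 3 (0.81 log units; beyond the scatter).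

The unmeasured compound 4 `COc1cc(CN(C)C(=O)c2cc3c(Cc4ccccc4)n[nH]c3cc2O)ccc1Cl` carries the change (4-chloro-3-methoxyphenyl in place of 2-fluorophenyl on a saturated chain carbon bound to an amide-type nitrogen). Within the data shown here, the steps that bear on it are the two that replace the 2-substituted ring with the 3-bromophenyl ring, both modest weakenings beyond the scatter; the step from compound 1 to compound 2 shows that exchanging fluoro for chloro on the same aromatic carbon changes nothing that can be resolved. Among the measured compounds shown here, compound 4 moves away from the 2-substituted pattern toward a ring substituted at the 3- and 4-carbons, and no measured compound carries a methoxy group, so the expectation leans on the two weakening steps only.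

On that basis a modest weakening, a 3.3-fold higher number from compound 1 to compound 4 (0.52 log units; beyond the scatter), is expected. For compound 4 the estimate in this assay is 5000 nM, with a range of 1800 nM to 14000 nM.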

Compound 4, half-maximal inhibitory concentration: 4100 nM
Beside the measured number, compound 4's estimate is 1.2-fold (0.09 log units) above it; the measured number falls inside the stated range.
By their numbers in this assay, from the lowest: compounds 2 and 1 (each within the scatter of the next); then compounds 4 and 3 (each within the scatter of the next).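

At this position on the saturated chain carbon bound to an amide-type nitrogen, in this assay, a second ring now separates from the 2-halophenyl rings: 4-chloro-3-methoxyphenyl reads weaker than 2-fluorophenyl (a 2.7-fold higher number from compound 1 to compound 4 (0.44 log units; beyond the scatter)) and weaker than 2-chlorophenyl (a 3.7-fold higher number from compound 2 to compound 4 (0.57 log units; beyond the scatter)), so this weakening no longer rests on 3-bromophenyl alone. The exchange of 3-bromophenyl for 4-chloro-3-methoxyphenyl (a 1.7-fold lower number from compound 3 to compound 4 (0.24 log units; within the scatter)) cannot be resolved, so the series now falls into two groups, compounds 1 and 2 on one side and compounds 3 and 4 on the other, and the methoxy group with its one hydrogen-bond acceptor brings no resolvable change against compound 3. No supporting evidence is available to explain why these two pairs of rings part in this way.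

Still open, as far as these compounds go, is how a 4-chlorophenyl or a 3-methoxyphenyl ring would read on its own, which would show which part of the 4-chloro-3-methoxyphenyl ring tracks with the weaker numbers. Also open, from the compounds shown here alone, is how this position would respond to a ring carrying an amine or a carboxylic acid, or to a longer chain in place of the saturated chain carbon.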